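The source may hold more compounds than are shown below. What is called first, only, known or untested is meant among the compounds shown, and "the series" means these compounds.

Compound 1 `O=c1c2ccccc2nc(CO[N+](=O)[O-])n1NS(=O)(=O)c1ccccc1`: 2.4%
Compound 2 `Cc1nc2ccccc2c(=O)n1NS(=O)(=O)c1ccccc1`: 5.6%

In a functional assay on the whole organism (strain Sprague-Dawley) for inhibition, with Rattus norvegicus as the target, read by paw edema, with stated times of 30 min and 1 h, at a dose of 80 mg/kg by the oral route (a lower number here means less inhibition, a higher number more inhibition at the dose given (going by the name of the read-out)), compound 1 gives 2.4% and compound 2 gives 5.6%. Both numbers are small, and the two compounds lie within the scatter of each other: a number 3.2 percentage points higher from compound 1 to compound 2 (within the scatter). Compound 2 therefore has no clear lead over compound 1 on these numbers.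

Compound 3 `Cc1ccc(S(=O)(=O)Nn2c(C)nc3ccccc3c2=O)cc1` has not been measured. It differs from compound 2 in one place: methyl in place of hydrogen on an aromatic carbon. Among the measured compounds shown here, the only measured step, from compound 1 to compound 2, concerns a saturated chain carbon and not the aromatic ring, so no measured step speaks to this change. For the measured compounds named here, with both measured compounds near the bottom of the scale and no step pointing in either direction, compound 3 is expected to stay close to compound 2, with a number 0.4 percentage points higher from compound 2 to compound 3 (within the scatter) not expected to exceed the scatter. Compound 3 is estimated at 6%, within 0% to 18%.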

Compound 3, a percentage reported as inhibition, in the whole organism at one dose (the size of the read-out at that dose, not a potency): 3.2%
Compound 3: the middle estimate sits 2.8 percentage points above what was measured; the range from low to high includes it.
By their numbers in this assay, from the lowest: compounds 1, 3 and 2 (each within the scatter of the next).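

In this assay, a methyl on the aromatic carbon para to a large group gives a number 2.4 percentage points lower from compound 2 to compound 3 (within the scatter), so the change from phenyl to 4-methylphenyl shows no effect that can be told apart from the scatter. Among the compounds shown here, the earlier step concerned a saturated chain carbon, whereas this one is the first look at the six-membered aromatic ring of carbon only, and the read-out stays near the bottom of the scale there too. Nothing measured here offers an explanation for this result.

As far as these compounds go, whether another group at this same place, such as a chlorine atom, an amine or a carboxylic acid, would give a step beyond the scatter remains open. From the compounds shown here alone, it is also open whether a longer chain in place of the methyl on the shared core would do so.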